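Replacing a sulfonate ester with a chlorophenyl ring

This account rests on a few compounds, and the source may have more. Where it says the series, first, only, none or still open, it means among the compounds named here.

Compound 1 `C=C[C@@](C)(/C=C/c1ccc(OS(=O)(=O)C(F)(F)F)cc1)CCC=C(C)C` gives, as a limit of the assay, > 36600 nM in an ADME assay on HEK293 cells (Homo sapiens) for cytotoxicity, with a stated time of 72 h; on this read-out higher numbers stand for an effect only at larger amounts of compound and lower numbers for an effect already at smaller amounts.
Compound 2 `C=C[C@@](C)(/C=C/c1ccc(OS(=O)(=O)c2ccc(C)cc2)cc1)CCC=C(C)C` gives, as a limit, > 36600 nM in this assay.
Compound 3 `C=C[C@@](C)(/C=C/c1ccc(O)cc1)CC/C=C(\C)C(=O)OCC` gives, as a limit, > 36600 nM in this assay.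

Compound 1 stands at the limit of > 36600 nM in this assay, at which 3 of the 3 values shown sit; no number is known for it, only that limit. Compound 4 `C=C[C@@](C)(/C=C/c1ccc(-c2ccc(Cl)cc2)cc1)CCC=C(C)C` differs from compound 1 by 4-chlorophenyl in place of ((trifluoromethyl)sulfonyl)oxy on an aromatic carbon. Among the compounds with values here, the only measured step between neighbours, a step that the two limits leave unreadable from compound 1 to compound 2, is unreadable, so no measured step gives a size for this change, and no step beyond the scatter is expected. Compound 4 is therefore expected to give about 40000 nM, in a range from 12000 nM to 120000 nM, most likely again reported only as a limit. This estimate means a step that the limit leaves unreadable from compound 1 to compound 4.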

Compound 4, half-maximal effective concentration: > 36600 nM
Compound 4 ended at the assay's limit; the forecaster's own chance of this, stated with the estimate: 70%; the middle value is on the limit's open side.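

Within the data shown here, compound 1 and compound 4 both end at a limit rather than a number, so no step between them can be read: the limit of > 36600 nM in this assay, at which 4 of the 4 values shown sit. The compounds shown leave open whether 4-chlorophenyl in place of ((trifluoromethyl)sulfonyl)oxy changes the result in this assay at all.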